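A Nitrobenzyl Swap on a Weakly Active Compound

The compounds below may be only part of what the source reports. "The series", "measured", "known", "first", "only" and "open" are said of these compounds alone.

So far, two close relatives have been tested in a functional assay on IMR-32 cells (Homo sapiens) for antiproliferative activity, read by MTT assay; a higher number here means a weaker inhibitor, a lower number a stronger inhibitor. Compound 1 (`Cc1c(-n2cc(COc3ccc(/C=C/C(=O)c4cc5c(cc4O)OC(C)(C)CC5)cc3)nn2)cccc1[N+](=O)[O-]`) is reported as "not active" (no number reported), with no number attached. For the measured compounds named here, compound 2 (`Cc1c(-n2cc(COc3ccc(/C=C/C(=O)c4ccc5c(c4O)CCC(C)(C)O5)cc3)nn2)cccc1[N+](=O)[O-]`) gives 73500 nM, the only number available, so there is no second figure to rank it against.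

Compound 3 (`CC1(C)CCc2c(ccc(C(=O)/C=C/c3ccc(OCc4cn(Cc5ccc([N+](=O)[O-])cc5)nn4)cc3)c2O)O1`) keeps the shared core of compound 2 but carries 4-nitrobenzyl in place of 2-methyl-3-nitrophenyl on an aromatic nitrogen. The two have the same atoms, joined differently. Going by the values given here, no measured pair shows what this swap does in this assay, so any forecast here is loose and has a single numerical anchor, compound 2 at 73500 nM. No change beyond the usual scatter is expected, and the estimated step is a 1.3-fold lower number from compound 2 to compound 3 (0.13 log units; within the scatter). A result without a number also remains possible, as compound 1 with "not active" (no number reported) shows. The expected value for compound 3 is 55000 nM, with an estimated range from 15000 nM to 150000 nM.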

Compound 3, half-maximal inhibitory concentration: 17300 nM
Estimate against measurement, compound 3: 3.2-fold (0.50 log units) above; the range from low to high includes it.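

In this assay, for the compounds shown here, the change to 4-nitrobenzyl in place of 2-methyl-3-nitrophenyl gives a 4.2-fold lower number from compound 2 to compound 3 (0.63 log units; beyond the scatter) and so provides the only measured step at this position, on an aromatic nitrogen of the five-membered ring with 3 nitrogen. The two groups have the same heavy atoms, one six-membered aromatic ring of carbon each, and the same counts of hydrogen-bond donors and acceptors, so this position responds to how those atoms are joined and not only to which atoms are present. The data shown offer no measurement that explains why the number falls.

Several features change together in this one swap: the ring is now held on a carbon link, the methyl group is gone, and the nitro group has a new place on the ring, so the share of each in the step remains open. A plain benzyl group, 3-nitrobenzyl, or 4-aminobenzyl with an amine replacing the nitro group would help to separate these features, and none of them is among the compounds shown.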